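Group swap on sulfur: compound 3 to compound 4

This account rests on a few compounds, and the source may have more. Where it says the series, first, only, none or still open, it means among the compounds named here.

Values in a functional assay on SMMC-7721 cells (Homo sapiens) for inhibition, read by CCK-8 assay, with a stated time of 72 h, tested at 8 uM; on this read-out lower numbers stand for less inhibition of growth and higher numbers for more inhibition of growth at the one concentration tested:
- compound 1 `Nc1ccccc1NC(=O)/C=C/c1ccc(CSc2ccc(Cl)cc2)cc1`: 16.5%
- compound 2 `Nc1ccccc1NC(=O)/C=C/c1ccc(CSc2ccc(F)cc2)cc1`: 15.4%
- compound 3 `Nc1ccccc1NC(=O)/C=C/c1ccc(CSCCc2ccccc2)cc1`: 15.8%

Compound 3 lies within the scatter of both compound 1 and compound 2, so these three values do not separate. The next structure is compound 4 `CC(C)(C)c1ccc(SCc2ccc(/C=C/C(=O)Nc3ccccc3N)cc2)cc1`. The change is 4-(tert-butyl)phenyl in place of phenethyl on a sulfur. Two measured steps change the group on that sulfur: a number 0.7 percentage points lower from compound 1 to compound 3 (within the scatter) and a number 0.4 percentage points higher from compound 2 to compound 3 (within the scatter). Fluoro in place of chloro on an aromatic carbon gives a number 1.1 percentage points lower from compound 1 to compound 2 (within the scatter). Going by the values given here, no measured compound carries 4-(tert-butyl)phenyl, but with these steps as the only guide, no step beyond the scatter is expected in this assay. The expected step is a number 1.2 percentage points higher from compound 3 to compound 4 (within the scatter). Compound 4 is estimated at 17%, with an expected range of 7% to 29%.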

Compound 4, percent growth inhibition at one concentration: 23.6%
For compound 4 the middle estimate is 6.6 percentage points below the measured one; low and high end bracket the measured number.
By their numbers in this assay, from the lowest: compounds 2, 3, 1 and 4 (each within the scatter of the next).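

In this assay, going by these compounds alone, the entry of 4-(tert-butyl)phenyl on the sulfur gives the largest steps so far, namely a number 7.8 percentage points higher from compound 3 to compound 4 (within the scatter) and a number 8.2 percentage points higher from compound 2 to compound 4 (within the scatter) and a number 7.1 percentage points higher from compound 1 to compound 4 (within the scatter), all still within the scatter. The position therefore accepts this group, and compound 4 does not separate from the three earlier compounds at this single concentration. Nothing available gives a reason for the size of these steps. Going by these compounds, it remains open whether an amine or a carboxylic acid in place of tert-butyl, or a longer chain on the sulfur, would give a step beyond the scatter.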